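Cyclohexyl to 4-ethylphenyl on the thiohydantoin nitrogen

This account rests on a few compounds, and the source may have more. Where it says the series, first, only, none or still open, it means among the compounds named here.

Three compounds of the series carry a measurement in an assay for inhibition of NADPH oxidase 4 (Homo sapiens), read by chemiluminescence; on this read-out lower numbers stand for stronger inhibition and higher numbers for weaker inhibition. Compound 1 `CN1C(=S)N(C2CCCCC2)C(=O)/C1=C/c1ccc(O)cc1O` gives 37600 nM. Compound 2 `CN1C(=S)N(C2CCCCC2)C(=O)/C1=C/c1ccc(N(C)C)cc1` gives 35600 nM; the difference between the cores of compound 1 and compound 2 is not broken down here, and their two numbers lie within the usual scatter of each other. Compound 3 `CCc1ccc(N2C(=O)/C(=C/c3ccc(O)cc3O)N(C)C2=S)cc1` gives 2390 nM. The change 4-ethylphenyl in place of cyclohexyl on an amide-type nitrogen in a ring produced a 16-fold lower number from compound 1 to compound 3 (1.20 log units; beyond the scatter), a large step that is well beyond the scatter.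

Compound 4 `CCc1ccc(N2C(=O)/C(=C/c3ccc(N(C)C)cc3)N(C)C2=S)cc1` has not been measured. It stands to compound 2 as compound 3 stands to compound 1: the change is 4-ethylphenyl in place of cyclohexyl on an amide-type nitrogen in a ring, with the place of the change the same word for word in both pairs, so this is the same change made a second time.

The expectation for compound 4 rests on one precedent only. Because the step of a 16-fold lower number from compound 1 to compound 3 (1.20 log units; beyond the scatter) was large and beyond the scatter, the step from compound 2 to compound 4 is expected to be a 15-fold lower number from compound 2 to compound 4 (1.19 log units; beyond the scatter). Compound 4 is therefore estimated at 2300 nM, with a plausible range from 800 nM to 7000 nM, the width reflecting that a single earlier step carries the whole estimate.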

Compound 4, inhibition constant: 2630 nM
Compound 4: middle estimate off by 1.1-fold (0.06 log units), on the low side, and the stated range covers the measured number.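

In this assay, 4-ethylphenyl in place of cyclohexyl on the amide-type nitrogen gives a 14-fold lower number from compound 2 to compound 4 (1.13 log units; beyond the scatter), and this step matches the earlier one, so the change carries over between the core of compound 1 and the core of compound 2 at much the same size: the same change on two cores in this assay, a 16-fold lower number (1.20 log units; beyond the scatter) from compound 1 to compound 3 and a 14-fold lower number (1.13 log units; beyond the scatter) from compound 2 to compound 4, 1.2-fold (0.07 log units) apart, within the scatter of two such steps Within these four compounds, the effect of this change on the number therefore does not depend on which of the two cores carries it. This does not show that the step would hold on a third core, and two pairs in one assay do not say why the number falls.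

Still open, going by these compounds, is whether the step comes from the aromatic ring or from its ethyl group: a plain phenyl, or a longer chain in place of the ethyl, on the same nitrogen would separate the two. Also open, on these data alone, is the size of the step on a core carrying a carboxylic acid or an amide in place of the hydroxyl or dimethylamino groups.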